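Cyclohexylmethyl in Place of Hydrogen on a Benzylated Sugar Core

This account rests on a few compounds, and the source may have more. Where it says the series, first, only, none or still open, it means among the compounds named here.

Measured compounds:
- compound 1, `O[C@H]1CO[C@H](COCc2ccccc2)[C@@H](OCc2ccccc2)[C@@H]1OCc1ccccc1`: "not active" (no number reported)
- compound 2, `c1ccc(COC[C@H]2OCC[C@@H](OCc3ccccc3)[C@@H]2OCc2ccccc2)cc1`: 39300 nM
- compound 3, `O[C@@H]1[C@@H](OCc2ccccc2)[C@H](OCc2ccccc2)[C@@H](COCc2ccccc2)O[C@H]1c1ccccc1`: 26300 nM

In a functional assay on HL-60 cells (Homo sapiens) for antiproliferative activity, read by MTT assay (on this read-out higher numbers stand for weaker inhibition and lower numbers for stronger inhibition), compound 1 is reported as "not active" (no number reported), so no number marks where it stands; it is simply without a measured effect in this assay. Compound 2 gives 39300 nM in this assay, and compound 3 gives 26300 nM, both weak. Compound 4, `O[C@@H]1[C@@H](OCc2ccccc2)[C@H](OCc2ccccc2)[C@@H](COCc2ccccc2)O[C@@H]1CC1CCCCC1`, differs from compound 1 by cyclohexylmethyl in place of hydrogen on a saturated ring carbon. Among the compounds with values here, no measured pair shows this change, so its size is not known; since compound 1 has no number, any step is expected to come out at best as a weak value near those of compound 2 and compound 3, or as no activity again. Compound 4 is therefore estimated at 30000 nM, within 8000 nM to 100000 nM.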

Compound 4, half-maximal inhibitory concentration: 17200 nM
For compound 4 the middle estimate is 1.7-fold (0.24 log units) above the measured one, within the range that was stated.
By their numbers in this assay, from the lowest: compounds 4, 3 and 2 (each within the scatter of the next, the first and the last beyond it).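

Within the data shown here, compound 1 carries no number, so no step from it to compound 4 can be read. The compounds shown leave open what cyclohexylmethyl in place of hydrogen contributes on its own, and no evidence at hand bears on this result.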